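Phenethyl in Place of Hydroxy on the Benzyl Ring

The source may hold more compounds than are shown below. What is called first, only, known or untested is meant among the compounds shown, and "the series" means these compounds.

Three compounds sharing one core were measured in a functional assay on HEK293 cells for antagonist activity at proteinase-activated receptor 4 (Homo sapiens), read by FLIPR and calcium flux, with a stated time of 30 min; on this read-out higher numbers stand for weaker inhibition and lower numbers for stronger inhibition. Compound 1 `COc1cc(OCc2ccccc2OC)c2cc(-c3cn4nc(OC)sc4n3)oc2c1` gives 19 nM. Compound 2 `COc1cc(OCc2cccc(COc3ccccc3)c2)c2cc(-c3cn4nc(OC)sc4n3)oc2c1` gives 3.2 nM. Compound 3 `COc1cc(OCc2cccc(O)c2)c2cc(-c3cn4nc(OC)sc4n3)oc2c1` gives 3.1 nM, the lowest of the three numbers; its gap to compound 2 lies within the scatter, while the step of a 6.1-fold lower number from compound 1 to compound 3 (0.79 log units; beyond the scatter) lies beyond it.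

Compound 4 `COc1cc(OCc2cccc(CCc3ccccc3)c2)c2cc(-c3cn4nc(OC)sc4n3)oc2c1` differs from compound 3 at one place: phenethyl in place of hydroxy on an aromatic carbon, the site being meta to a large group. The step that bears on it is a 1.0-fold lower number from compound 2 to compound 3 (0.01 log units; within the scatter), where a group holding an aromatic ring on a short link gave a number indistinguishable from the hydroxy compound. Phenethyl is another group of that kind, so the expected step in this assay for compound 4 is a 1.3-fold higher number from compound 3 to compound 4 (0.11 log units; within the scatter), no change beyond the scatter in either direction. Compound 4 is therefore estimated at 4 nM, within a range from 1.5 nM to 12 nM.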

Compound 4, half-maximal inhibitory concentration: 2.4 nM
Estimate against measurement, compound 4: 1.7-fold (0.22 log units) above; the range from low to high includes it.
By their numbers in this assay, from the lowest: compounds 4, 3 and 2 (each within the scatter of the next); then compound 1.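

In this assay this position on the benzyl ring takes phenethyl as well as hydroxy: the change gives a 1.3-fold lower number from compound 3 to compound 4 (0.11 log units; within the scatter), so a group with no hydrogen-bond donor or acceptor reads level with one that has one of each. Putting benzyl in place of phenoxy on the chain carbon gives a 1.3-fold lower number from compound 2 to compound 4 (0.12 log units; within the scatter), so an all-carbon link and one holding an oxygen also read alike. Nothing at hand explains why these groups read alike.

As far as these compounds go, what remains open is how far this tolerance extends, since hydroxy and two much larger groups all fall within the scatter of one another. An amine, a carboxylic acid or a longer chain on the same aromatic carbon could stay level with these compounds or depart from them.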